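Chain length at the ring nitrogen and a cyclopropyl replacement

The compounds below may be only part of what the source reports. "The series", "measured", "known", "first", "only" and "open" are said of these compounds alone.

Measured so far in an assay on Cerebral cortex for displacement of a labelled ligand from adenosine receptor A1 (Bos taurus); on this read-out higher numbers stand for weaker inhibition and lower numbers for stronger inhibition:
compound 1 `CCNc1nc(-c2ccccc2)nc2c1nnn2Cc1ccccc1`: 91 nM
compound 2 `CCCNc1nc(-c2ccccc2)nc2c1nnn2Cc1ccccc1`: 37 nM
compound 3 `CCCCCCNc1nc(-c2ccccc2)nc2c1nnn2Cc1ccccc1`: 13.2 nM

Compound 3 gives the lowest number of the three, beyond the scatter from both others. The steps move one way: a 2.5-fold lower number from compound 1 to compound 2 (0.39 log units; beyond the scatter) and a 2.8-fold lower number from compound 2 to compound 3 (0.45 log units; beyond the scatter), together a 6.9-fold lower number from compound 1 to compound 3 (0.84 log units; beyond the scatter). Each lengthening of the chain on the ring nitrogen lowers the number by a modest amount.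

Compound 4 `c1ccc(Cn2nnc3c(NC4CC4)nc(-c4ccccc4)nc32)cc1` differs from compound 3 by cyclopropyl in place of hexyl on a nitrogen on an aromatic ring. Going by the values given here, no measured step swaps a chain for a ring, so the three chain-lengthening steps are the only guide. The entering group carries the same count of carbons as the chain of compound 2, so the loss of the hexyl chain is expected to raise the number, probably by about the size of the reverse of the step from compound 2 to compound 3, and less likely to lower it. The step expected from compound 3 to compound 4 is a 3.0-fold higher number from compound 3 to compound 4 (0.48 log units; beyond the scatter). Compound 4 is therefore estimated at 40 nM, within 14 nM to 120 nM.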

Compound 4, inhibition constant: 11.3 nM
Estimate against measurement, compound 4: 3.5-fold (0.55 log units) above; measured number below the stated range.
By their numbers in this assay, from the lowest: compounds 4 and 3 (each within the scatter of the next); then compound 2; then compound 1.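

On the nitrogen on an aromatic ring, in this assay, cyclopropyl and hexyl cannot be told apart (a 1.2-fold lower number from compound 3 to compound 4 (0.07 log units; within the scatter)), so the much smaller ring matches the longest chain shown. Cyclopropyl also gives lower numbers than the shorter chains (a 3.3-fold lower number from compound 2 to compound 4 (0.52 log units; beyond the scatter); an 8.1-fold lower number from compound 1 to compound 4 (0.91 log units; beyond the scatter)), which makes compound 4 the exception to the link between chain length and number seen across compound 1, compound 2 and compound 3. Nothing at hand explains why the ring matches hexyl.

As far as these compounds go, it remains open whether cyclobutyl, cyclopentyl or cyclohexyl on this nitrogen would hold the number seen with cyclopropyl, and whether a branched isopropyl would behave like the ring or like the propyl chain. Also open, from the compounds shown here alone, is whether chains longer than hexyl would lower the number further or reverse the trend.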